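The source may hold more compounds than are shown below. What is called first, only, known or untested is meant among the compounds shown, and "the series" means these compounds.

Notes on the series around compound 1 (`Nc1ccccc1NC(=O)/C=C/c1ccc(CSc2cccc(F)c2)cc1`) and compound 2 (`Nc1ccccc1NC(=O)/C=C/c1ccc(CSCCc2ccccc2)cc1`). In a functional assay on SMMC-7721 cells (Homo sapiens) for inhibition, read by CCK-8 assay, with a stated time of 72 h, tested at 2 uM (on this read-out lower numbers stand for less inhibition of growth and higher numbers for more inhibition of growth at the one concentration tested), compound 1 gives 8.56% and stands level with compound 2 at 14.7% on this read-out. Going by the values given here, compound 2 therefore lies within the scatter of the only other measured compound, and no order can be drawn between the two.

The next structure is compound 3 (`CC(C)(C)c1ccc(SCc2ccc(/C=C/C(=O)Nc3ccccc3N)cc2)cc1`), which has 4-(tert-butyl)phenyl in place of phenethyl on a sulfur. Among the compounds with values here, the one measured step at this sulfur (a number 6.1 percentage points higher from compound 1 to compound 2 (within the scatter)) put phenethyl in place of 3-fluorophenyl and did not leave the scatter. Within the data shown here, no measured compound carries 4-(tert-butyl)phenyl, so the data give no direct guide to that group. On the size of that single step, no shift beyond the scatter is expected in this assay for the new change, and no direction can be favoured. The expected step is small (a number 0.7 percentage points lower from compound 2 to compound 3 (within the scatter)) and remains uncertain. For compound 3 the estimate is 14% with an expected range from 3% to 30% in this measurement.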

Compound 3, percent growth inhibition at one concentration: 18.3%
The estimate for compound 3 lay 4.3 percentage points below the measured number, within the range that was stated.
By their numbers in this assay, from the lowest: compounds 1, 2 and 3 (each within the scatter of the next).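

Compound 3 brings a third group onto this sulfur, 4-(tert-butyl)phenyl, which has 10 heavy atoms against the 8 of phenethyl and keeps one six-membered aromatic ring of carbon only. In this assay that change gives a number 3.6 percentage points higher from compound 2 to compound 3 (within the scatter) and, set against 3-fluorophenyl, it gives a number 9.7 percentage points higher from compound 1 to compound 3 (within the scatter), so even the largest step now available at this sulfur does not leave the scatter and the three groups stand level on this read-out. Nothing at hand offers an explanation for why these groups read alike.

Every group shown at this sulfur carries a single carbon aromatic ring, so it remains open whether a group of another kind there, such as a primary amine, a carboxylic acid or a short unbranched alkyl chain, would move the reading beyond the scatter. On these data alone, it also remains open whether the level standing of compound 1, compound 2 and compound 3 would hold at other concentrations, where a full dose-response curve could separate groups that a single-point reading cannot.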